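Swapping a Methylamino Group for Hydrogen

The source may hold more compounds than are shown below. What is called first, only, known or untested is meant among the compounds shown, and "the series" means these compounds.

In a functional assay on HUVEC cells (Homo sapiens) for inhibition, read by WST assay, with a stated time of 72 h (on this read-out higher numbers stand for weaker inhibition and lower numbers for stronger inhibition), compound 1 (`CNc1nc(Nc2cccc(NS(C)(=O)=O)c2)nc(Nc2cc(OC)c(OC)c(OC)c2)n1`) gives 10000 nM. It stands level with compound 2 (`COc1cc(Nc2ncnc(Nc3ccccc3NS(C)(=O)=O)n2)cc(OC)c1OC`), which gives 6100 nM. These two values lie within the usual scatter of each other, so neither can be ranked ahead.

Compound 3 (`COc1cc(Nc2ncnc(Nc3cccc(NS(C)(=O)=O)c3)n2)cc(OC)c1OC`) changes compound 1 in one place: hydrogen in place of methylamino on an aromatic carbon. Hydrogen takes the place of methylamino on an aromatic carbon, between two ring nitrogen atoms. Compound 3 has not yet been measured. Compound 2 also has no methylamino group and gives 6100 nM, so removing that group is not expected to change the number much. The expected step in this assay is small and towards a lower number, a 1.7-fold lower number from compound 1 to compound 3 (0.22 log units; within the scatter), which would stay within the scatter. Compound 3 is estimated at 6000 nM, with an expected range of 2000 nM to 15000 nM.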

Compound 3, half-maximal inhibitory concentration: 7200 nM
Compound 3: middle estimate off by 1.2-fold (0.08 log units), on the low side, and the stated range covers the measured number.
By their numbers in this assay, from the lowest: compounds 2, 3 and 1 (each within the scatter of the next).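

Before this pair, no two measured compounds differed in one place only, so the methylamino group could not be judged on its own. Hydrogen in place of methylamino on an aromatic carbon, between two ring nitrogen atoms, now gives a 1.4-fold lower number from compound 1 to compound 3 (0.14 log units; within the scatter) in this assay and so makes no change that can be told from the ordinary spread of repeat measurements. Nothing available explains this outcome.

On these data alone, it remains open whether a plain amine or a methyl group at this position would also stay within that spread. The same holds for larger groups, such as a dimethylamino group, a longer chain or a carboxylic acid, any of which could move the number further than methylamino and hydrogen do.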